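Oxindole series: forecasting a dichlorophenyl swap at the core carbon

The compounds below may be only part of what the source reports. "The series", "measured", "known", "first", "only" and "open" are said of these compounds alone.

Measured so far in an in vitro functional assay on CHO-CREluc cells for antagonist activity at growth hormone secretagogue receptor type 1 (Homo sapiens), read by a luciferase reporter, with a stated time of 4 h; on this read-out lower numbers stand for stronger inhibition and higher numbers for weaker inhibition:
- compound 1 `Cc1cc2c(cc1Cl)NC(=O)C2(NC(=O)CN1CCN(C)CC1)c1cccc(Cl)c1`: compound 1 gives 1180 nM
- compound 2 `CCN1CCN(CC(=O)NC2(c3ccc(Cl)c(Cl)c3)C(=O)Nc3cc(Cl)cc(Cl)c32)CC1=O`: compound 2 gives 2780 nM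
- compound 3 `Cc1cc2c(cc1Cl)NC(=O)C2(NC(=O)CN1CCNCC1)c1ccc(Cl)cc1`: for compound 3 only a limit is reported, > 10000 nM

Among the two numbers shown, compound 1 stands lowest, and the gap up to compound 2 is beyond the usual scatter. The limit for compound 3 is one of the values recorded in this assay (the limit of > 10000 nM in this assay, at which 1 of the 3 values shown sits). For the measured compounds named here, no pair of measured compounds differs in one place, so no measured step is available to lean on.

Compound 4 `Cc1cc2c(cc1Cl)NC(=O)C2(NC(=O)CN1CCN(C)CC1)c1ccc(Cl)cc1Cl` carries the change (2,4-dichlorophenyl in place of 3-chlorophenyl on a saturated ring carbon), that is, 2,4-dichlorophenyl in place of 3-chlorophenyl on a saturated ring carbon. Compound 2 and compound 3 differ from compound 1 in more than the aryl group, so their values say nothing directly about this step. The step is expected to be modest: compound 4 is estimated to move from compound 1 by a 1.7-fold higher number from compound 1 to compound 4 (0.23 log units; within the scatter), in the direction of a weaker number. Compound 4 is therefore expected to give about 2000 nM, within 600 nM to 7000 nM.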

Compound 4, half-maximal inhibitory concentration: > 10000 nM
Compound 4: no number, only a limit; the forecaster's own chance of this, stated with the estimate: 15%; middle value at least 5.0-fold (0.69 log units) away from the limit.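

In this assay compound 4 gives > 10000 nM, which is a limit and not a number, and it is a limit shared with another compound in the series: the limit of > 10000 nM in this assay, at which 2 of the 4 values shown sit. Replacing 3-chlorophenyl with 2,4-dichlorophenyl on the saturated ring carbon gives an at least 8.4-fold higher number from compound 1 to compound 4 (0.92 log units; beyond the scatter), the only step shown that changes one place. This position therefore does not accept every chlorinated phenyl group with the rest of compound 1 held fixed, something compound 2 and compound 3 could not show, as each differs from compound 1 in more than the aryl group.

Open is which chlorine of the 2,4-dichlorophenyl group accounts for the step, with a 2-chlorophenyl or a 4-chlorophenyl group on the core of compound 1 as the direct tests. Also open, going by these compounds, is how an unsubstituted phenyl or a pyridyl ring would read at this carbon.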